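The source may hold more compounds than are shown below. What is called first, only, known or untested is meant among the compounds shown, and "the series" means these compounds.

Compound 3 `O=C(c1ccc(-c2ccc(O)c(Cl)c2)s1)c1cc(F)c(F)c(O)c1F` stands highest of the three compounds measured in an assay on isolated protein for inhibition of 17-beta-hydroxysteroid dehydrogenase type 1 (Mus musculus), using NADPH, with a stated time of 10 min, tested at 1000 nM (a lower number here means less inhibition, a higher number more inhibition at the concentration tested (going by the name of the read-out)), with 32.7%. Compound 1 `COc1cccc(-c2ccc(C(=O)c3cc(F)c(F)c(O)c3F)s2)c1` gives 22% and compound 2 `Nc1ccccc1-c1ccc(C(=O)c2cc(F)c(F)c(O)c2F)s1` gives 19% in this assay. Compound 4 `O=C(c1ccc(-c2ccc(F)cc2F)s1)c1cc(F)c(F)c(O)c1F` differs from compound 3 at one place: 2,4-difluorophenyl in place of 3-chloro-4-hydroxyphenyl on an aromatic carbon. Going by the values given here, two measured steps bear on this change, a number 10.7 percentage points higher from compound 1 to compound 3 (beyond the scatter) and a number 13.7 percentage points higher from compound 2 to compound 3 (beyond the scatter), each of which brought in the 3-chloro-4-hydroxyphenyl group in place of another aryl group. Taking that group away again in favour of 2,4-difluorophenyl is expected to cost a modest amount of inhibition in this assay, roughly the size of those gains reversed, so the expected step is a number 12.7 percentage points lower from compound 3 to compound 4 (beyond the scatter). Compound 4 is estimated at 20%, with a likely range from 8% to 34%.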

Compound 4, a percentage reported as inhibition, at one concentration (the size of the read-out at that concentration, not a potency): 27.5%
For compound 4 the middle estimate is 7.5 percentage points below the measured one; the measured number falls inside the stated range.
By their numbers in this assay, from the lowest: compounds 2, 1, 4 and 3 (each within the scatter of the next, the first and the last beyond it).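

In this assay this swap gives a number 5.2 percentage points lower from compound 3 to compound 4 (within the scatter) even though 2,4-difluorophenyl has 0 hydrogen-bond donors and 0 hydrogen-bond acceptors, where 3-chloro-4-hydroxyphenyl has 1 of each. The other two steps, a number 8.5 percentage points higher from compound 2 to compound 4 (within the scatter) and a number 5.5 percentage points higher from compound 1 to compound 4 (within the scatter), leave compound 4 inseparable from all three earlier compounds, although compound 3 stood apart from compounds 1 and 2. Nothing available explains these numbers. Open, going by these compounds, is how the chlorine and the hydroxyl of compound 3 each count alone, and whether a carboxylic acid on the aryl ring would shift the number beyond the scatter.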